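Amine substituent on the shared core: aryl versus saturated ring

The source may hold more compounds than are shown below. What is called first, only, known or untested is meant among the compounds shown, and "the series" means these compounds.

The shared core carries an amine on a double-bonded ring carbon. In a functional assay on MGC-803 cells (Homo sapiens) for inhibition, read by sulforhodamine B assay (a lower number here means a stronger inhibitor, a higher number a weaker inhibitor), compound 1 `O=C1C(Nc2cccc(Cl)c2)=CC(=O)c2c1nc1n2[C@H]2OC[C@@H](O)[C@H]2OC1` gives 1530 nM. Compound 3 `COc1ccccc1NC1=CC(=O)c2c(nc3n2[C@H]2OC[C@@H](O)[C@H]2OC3)C1=O` gives 1670 nM, which sits with compound 1 within the scatter, a 1.1-fold higher number from compound 1 to compound 3 (0.04 log units; within the scatter). Compound 2 `O=C1C(N2CCCCC2)=CC(=O)c2c1nc1n2[C@H]2OC[C@@H](O)[C@H]2OC1` returns only a limit, > 4000 nM, at the limit of > 4000 nM in this assay, at which 1 of the 3 values shown sits. Compound 4 `O=C1C(NC2CCCCC2)=CC(=O)c2c1nc1n2[C@H]2OC[C@@H](O)[C@H]2OC1` differs from compound 3 by cyclohexyl in place of 2-methoxyphenyl on an amine nitrogen. Among the compounds with values here, two measured steps bear on this exchange of an aryl group for a saturated ring on the amine position: an at least 2.6-fold higher number from compound 1 to compound 2 (0.41 log units; beyond the scatter) and an at least 2.3-fold lower number from compound 2 to compound 3 (0.37 log units; beyond the scatter). From these a modest rise in the number is expected, a 2.1-fold higher number from compound 3 to compound 4 (0.32 log units; beyond the scatter), with a real chance that only a limit is returned. Compound 4 is estimated at 3500 nM, between 1500 nM and 8000 nM.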

Compound 4, half-maximal inhibitory concentration: > 8000 nM
Compound 4 gave a limit, no number; the forecaster's own chance of this, stated with the estimate: 35%; middle value at least 2.2-fold (0.35 log units) away from the limit.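

In this assay the loss no longer rests on compound 2, whose piperidin-1-yl ring also lacks the amine hydrogen: cyclohexylamino keeps that hydrogen, yet the change gives an at least 4.7-fold higher number from compound 3 to compound 4 (0.68 log units; beyond the scatter), and likewise an at least 5.2-fold higher number from compound 1 to compound 4 (0.71 log units; beyond the scatter). Compound 4 is a limit, not a number: the limit of > 8000 nM in this assay, at which 1 of the 4 values shown sits. Compound 2 is a limit too, so the step between the two saturated rings cannot be read.

Still open, going by these compounds, is whether a benzylamino or an open-chain butylamino group on this amine nitrogen would read like the aryl amines or like cyclohexylamino.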